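The source may report more compounds than this note shows. Statements on the series, on what has been measured and on what is new or still open speak of the compounds shown alone.

Working notes on the series. In a functional assay on ECa-109 cells for inhibition, with ECa-109 cell line (Homo sapiens) as the target, read by sulforhodamine B assay (a lower number here means a stronger inhibitor, a higher number a weaker inhibitor), compound 1 `O=C1C=C(N2CCC2)C(=O)c2c1nc1n2[C@H]2OC[C@@H](O)[C@H]2OC1`, which carries azetidin-1-yl, gives > 16000 nM, and this is a limit of the assay and not a number. Among the measured compounds shown here, compound 2 `CCc1ccc(NC2=CC(=O)c3nc4n(c3C2=O)[C@H]2OC[C@@H](O)[C@H]2OC4)cc1` gives 3080 nM, so it holds the only true number so far. For the measured compounds named here, the sole other reading is the limit of > 16000 nM in this assay, at which 1 of the 2 values shown sits.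

Compound 3 `CCOc1ccc(NC2=CC(=O)c3nc4n(c3C2=O)[C@H]2OC[C@@H](O)[C@H]2OC4)cc1` is still unmeasured. It keeps the core of compound 2 and has ethoxy in place of ethyl on an aromatic carbon, para to a large group: ethoxy in place of ethyl on an aromatic carbon.

One measured step is available: an at least 5.1-fold lower number from compound 1 to compound 2 (0.71 log units; beyond the scatter). That step exchanged the whole group on a double-bonded ring carbon, so it bears only loosely on this smaller change. Going by the values given here, no measured step covers a change on the aromatic ring itself.

The expected move, a 1.0-fold lower number from compound 2 to compound 3 (0.01 log units; within the scatter), is therefore estimated to stay within the scatter, with no direction favoured in this assay. In this assay the estimate for compound 3 is 3000 nM, with an expected range of 1100 nM to 8000 nM.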

Compound 3, half-maximal inhibitory concentration: 3210 nM
The estimate for compound 3 lay 1.1-fold (0.03 log units) below the measured number; the range from low to high includes it.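

In this assay, 4-ethoxyphenyl in place of 4-ethylphenyl gives a 1.0-fold higher number from compound 2 to compound 3 (0.02 log units; within the scatter), so the two compounds read alike despite the oxygen and the hydrogen-bond acceptor that ethoxy brings. Among the compounds shown here, this is the first measured change on the aromatic ring itself, since the earlier step exchanged the whole group on a double-bonded ring carbon, and it shows that, for this one pair, ethyl and ethoxy can stand in for each other on this aromatic carbon, para to a large group, without a reading beyond the scatter. The series still holds only two true numbers, and the reading of compound 1 remains a limit and not a number: the limit of > 16000 nM in this assay, at which 1 of the 3 values shown sits.

On these data alone, two groups of similar size say little about how far this tolerance extends, so it stays open whether a primary amine, a carboxylic acid or a longer chain such as butoxy on the same aromatic carbon would also read alike. Also open is whether the match between ethyl and ethoxy holds on any other cell line, as all readings shown come from a single assay.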